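A few compounds are considered here, and "the series" means these few. Any claim that something is new, unique, unknown or untested is made for them only; others in the source may bear on it.

Measured so far:
Compound 1 `O=C(Nc1ccccc1)C1CCN(C/C=C/c2ccccc2)CC1` gives 60200 nM
Compound 2 `Cc1ccc(NC(=O)C2CCN(C/C=C/c3ccccc3)CC2)cc1` gives 30000 nM
Compound 3 `CCc1ccc(NC(=O)C2CCN(C/C=C/c3ccccc3)CC2)cc1` gives 20000 nM

In a functional assay on MCF7 cells (Homo sapiens) for inhibition, read by MTT assay, with a stated time of 72 h (a lower number here means a stronger inhibitor, a higher number a weaker inhibitor), compound 1 gives 60200 nM and stands at the upper end of these numbers, though it is not clear of compound 2 (a 2.0-fold lower number from compound 1 to compound 2 (0.30 log units; within the scatter)). It is clear of compound 3 (a 3.0-fold lower number from compound 1 to compound 3 (0.48 log units; beyond the scatter)). Compounds 2 and 3 do not separate (a 1.5-fold lower number from compound 2 to compound 3 (0.18 log units; within the scatter)).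

Compound 4 `CC(C)c1ccc(NC(=O)C2CCN(C/C=C/c3ccccc3)CC2)cc1` is the next case: isopropyl in place of hydrogen on an aromatic carbon, para to a large group (isopropyl in place of hydrogen on an aromatic carbon). The methyl and ethyl steps from compound 1 bear on it directly, and both run toward a lower number. Only the ethyl step leaves the scatter, and it is modest. No branched group has been measured, so the reading is loose. An estimated step of similar size (a 3.3-fold lower number from compound 1 to compound 4 (0.52 log units; beyond the scatter)) is expected in this assay toward a lower number. For compound 4 the estimated value is 18000 nM with an expected range from 8000 nM to 40000 nM in this measurement.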

Compound 4, half-maximal inhibitory concentration: 9100 nM
For compound 4 the middle estimate is 2.0-fold (0.30 log units) above the measured one; measured number inside the range.
By their numbers in this assay, from the lowest: compound 4; then compounds 3, 2 and 1 (each within the scatter of the next, the first and the last beyond it).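

In this assay, isopropyl on the aromatic carbon para to a large group gives the largest step seen so far at this position, a 6.6-fold lower number from compound 1 to compound 4 (0.82 log units; beyond the scatter), though it remains modest. Compound 4 also separates from both smaller alkyl analogues, with a 2.2-fold lower number from compound 3 to compound 4 (0.34 log units; beyond the scatter) and a 3.3-fold lower number from compound 2 to compound 4 (0.52 log units; beyond the scatter), so it is the strongest of the four, whereas compounds 2 and 3 did not separate from each other. No supporting evidence bears on the origin of this gain.

The compounds shown leave open whether the run toward lower numbers continues with tert-butyl or a longer chain, or stops there. They also leave open how a non-alkyl group such as an amine, a carboxylic acid or a fluorine atom would behave on this ring.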